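Replacing a 4-methylbenzyl arm with isobutyl on a cytotoxicity series

The compounds below may be only part of what the source reports. "The series", "measured", "known", "first", "only" and "open" are said of these compounds alone.

Measured so far:
Compound 1 `Cc1ccc(CN2CCC(C(=O)Nc3ccc(CNc4nc(N(C)C)nc5cc(C)ccc45)cc3)CC2)cc1`; in a functional assay on SV5A8 cells (Homo sapiens) for cytotoxicity (on this read-out lower numbers stand for stronger inhibition and higher numbers for weaker inhibition), compound 1 gives > 4150 nM, which is a limit of the assay.
Compound 2 `Cc1ccc2c(NCc3ccc(NC(=O)C4CCN(Cc5ccccc5)CC4)cc3)nc(N3CCN[C@@H](C)C3)nc2c1`; in this assay compound 2 gives > 8860 nM, also a limit.
Compound 3 `Cc1ccc2c(NCc3ccc(NC(=O)C4CCN(Cc5ccccc5)CC4)cc3)nc(N3CCCCCC3)nc2c1`; in this assay compound 3 gives > 6880 nM, again a limit.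

None of the three compounds therefore has a numerical value: each was tested only up to its limit, and for compound 1 that is the limit of > 4150 nM in this assay, at which 1 of the 3 values shown sits. Going by the values given here, the one step that can be drawn between measured compounds, a step that the two limits leave unreadable from compound 2 to compound 3, cannot be read because both ends are limits, and it concerns a change on an aromatic carbon of the shared core rather than the part that changes here.

Compound 4 `Cc1ccc2c(NCc3ccc(NC(=O)C4CCN(CC(C)C)CC4)cc3)nc(N(C)C)nc2c1` differs from compound 1 by isopropyl in place of 4-methylphenyl on a saturated chain carbon bound to an amine nitrogen in a ring. Among the compounds with values here, no measured step touches this position, so nothing in the data indicates a direction for this change. With compound 1 already at its limit, compound 4 is expected to sit near or beyond that limit too, which means a step that the limit leaves unreadable from compound 1 to compound 4 that is expected to be small. The estimate for compound 4 is 8000 nM, with a range from 2000 nM to 30000 nM.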

Compound 4, half-maximal inhibitory concentration: > 10500 nM
Compound 4 gave a limit, no number; the forecaster's own chance of this, stated with the estimate: 75%; middle value at least 1.3-fold (0.11 log units) from the limit.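

In this assay compound 4 gives > 10500 nM and that is a limit, not a number. Compound 1 also stands at a limit, so the change from 4-methylbenzyl to isobutyl between compound 1 and compound 4 cannot be read as a step. The compounds shown leave open how strongly any of them acts in this assay and whether this arm matters at all.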